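Swapping Methoxy for a Selenium Chain on the Shared Core

A few compounds are considered here, and "the series" means these few. Any claim that something is new, unique, unknown or untested is made for them only; others in the source may bear on it.

Among the compounds with values here, compound 3 `COc1c(SCC#CCO)cnc2ccccc12` gives 22 ug/mL in a functional assay on CCRF-CEM cells (Homo sapiens) for cytotoxicity, read by sulforhodamine B assay, with a stated time of 72 h (on this read-out higher numbers stand for weaker inhibition and lower numbers for stronger inhibition), the highest of the three numbers measured so far: compound 1 `OCC#CCSc1cnc2ccccc2c1SCC#CCO` gives 2.6 ug/mL and compound 2 `C[Se]c1c(SCC#CCO)cnc2ccccc12` gives 2.1 ug/mL. Compound 4 `C#CC[Se]c1c(SCC#CCO)cnc2ccccc12` differs from compound 3 in one place: a group of 4 heavy atoms (3 carbon, 1 selenium; no ring) in place of a group of 2 heavy atoms (1 carbon, 1 oxygen; no ring), on an aromatic carbon. The step that bears on this most is a 10-fold higher number from compound 2 to compound 3 (1.02 log units; beyond the scatter), in which methoxy took the place of a group of one carbon and one selenium; an 8.5-fold higher number from compound 1 to compound 3 (0.93 log units; beyond the scatter) points the same way. Returning a selenium-containing group in place of methoxy is therefore expected to produce a large step down, an 8.8-fold lower number from compound 3 to compound 4 (0.94 log units; beyond the scatter). Compound 4 is estimated at 2.5 ug/mL, with a likely range from 1 ug/mL to 6.5 ug/mL.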

Compound 4, concentration for 50% inhibition: 1.9 ug/mL
Beside the measured number, compound 4's estimate is 1.3-fold (0.12 log units) above it; the measured number falls inside the stated range.
By their numbers in this assay, from the lowest: compounds 4, 2 and 1 (each within the scatter of the next); then compound 3.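

In this assay, within the data shown here, putting this selenium group in place of methoxy gives a 12-fold lower number from compound 3 to compound 4 (1.06 log units; beyond the scatter) and so shows that the position tolerates a larger selenium group than the one in compound 2. Ethynyl on the chain carbon bound to selenium gives only a 1.1-fold lower number from compound 2 to compound 4 (0.04 log units; within the scatter) and the swap from the sulfur chain gives a 1.4-fold lower number from compound 1 to compound 4 (0.14 log units; within the scatter) as well, so these three groups cannot be told apart here. No measurement here says why methoxy stands apart from them. Going by these compounds, whether an amine or a longer chain on selenium would keep this level remains open.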